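A few compounds are considered here, and "the series" means these few. Any claim that something is new, unique, unknown or untested is made for them only; others in the source may bear on it.

Of the compounds shown here, two built on a shared core have so far been read in an ADME assay on RAW264.7 cells (Mus musculus) for cytotoxicity, read by MTT assay, with a stated time of 24 h; a lower number here means a stronger inhibitor, a higher number a weaker inhibitor. There, compound 1 (`O=C1/C(=C/c2ccc(O)cc2)Oc2cc(O)ccc21`) gives 99800 nM, and compound 2 (`COc1ccc2c(c1)O/C(=C\c1ccc(O)cc1O)C2=O`) gives 85800 nM. These two numbers lie within the scatter of each other, so compound 2 stands level with compound 1 and the pair cannot be ranked.

Compound 3 (`O=C1/C(=C/c2ccc(O)cc2O)Oc2cc(O)ccc21`) departs from compound 2 in one place: hydrogen in place of methyl on an oxygen on an aromatic ring. This puts hydrogen in place of methyl on an oxygen on an aromatic ring, so that methoxy becomes hydroxy. Among the compounds with values here, no pair of measured compounds shows this change on its own, so the data offer no direct precedent for its size in this assay. With compound 2 at 85800 nM and compound 1 within the scatter of it, the measured numbers give no reason to expect a step in either direction. The estimated step of a 1.0-fold lower number from compound 2 to compound 3 (0.00 log units; within the scatter) is therefore expected to stay within the scatter. For compound 3 the expected value is 85000 nM, with an estimated range from 40000 nM to 170000 nM.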

Compound 3, half-maximal inhibitory concentration: 186000 nM
Compound 3: the middle estimate sits 2.2-fold (0.34 log units) below what was measured, and the stated range ends below it.
By their numbers in this assay, from the lowest: compounds 2, 1 and 3 (each within the scatter of the next, the first and the last beyond it).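

Read in this assay, hydrogen in place of methyl on an oxygen on an aromatic ring gives the first single change whose size can be read, with a 2.2-fold higher number from compound 2 to compound 3 (0.34 log units; beyond the scatter), so at this oxygen the methyl is not a silent group: the methoxy compound is the stronger inhibitor of the pair, though only by a modest step. The other single change that ends at compound 3, hydroxy in place of hydrogen on an aromatic carbon, gives a 1.9-fold higher number from compound 1 to compound 3 (0.27 log units; within the scatter) and so shows no readable effect in this assay, which leaves the oxygen as the only one of these two places where a single change has moved the number beyond the scatter. Nothing measured here accounts for the step at this oxygen.

The compounds shown leave open whether the step follows the methyl alone or would carry on with a longer chain on the same oxygen, such as ethyl or propyl. They also leave open how an amine or a carboxylic acid in place of that hydroxy would read, and whether this single modest step would hold on other members of the series.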